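Adding trifluoromethyl to the phenoxy group of compound 2

This account rests on a few compounds, and the source may have more. Where it says the series, first, only, none or still open, it means among the compounds named here.

Compound 1 `CC(C)[C@H](NC(=O)COc1cccc2ccccc12)C(=O)N[C@@H](CC(=O)O)C(=O)COc1ccc(C#N)cc1`: > 100000 nM, a limit of the assay
Compound 2 `CC(C)[C@H](NC(=O)COc1cccc2ccccc12)C(=O)N[C@@H](CC(=O)O)C(=O)COc1ccc(Oc2ccccc2)cc1`: 12700 nM

Among the compounds with values here, in a functional assay on Jurkat cells (Homo sapiens) (on this read-out higher numbers stand for weaker inhibition and lower numbers for stronger inhibition), compound 2 holds the only actual number, 12700 nM. The value of compound 1 is a limit, > 100000 nM. Compound 3 `CC(C)[C@H](NC(=O)COc1cccc2ccccc12)C(=O)N[C@@H](CC(=O)O)C(=O)COc1ccc(Oc2ccc(C(F)(F)F)cc2)cc1` has trifluoromethyl in place of hydrogen on an aromatic carbon, para to a large group: trifluoromethyl in place of hydrogen on an aromatic carbon. Within the data shown here, one measured step bears on this change, an at least 7.8-fold lower number from compound 1 to compound 2 (0.89 log units; beyond the scatter), and it rests on (the limit of > 100000 nM in this assay, at which 1 of the 2 values shown sits). Following the direction of an at least 7.8-fold lower number from compound 1 to compound 2 (0.89 log units; beyond the scatter), a modest further lowering in this assay is expected, an estimated 2.1-fold lower number from compound 2 to compound 3 (0.33 log units; beyond the scatter). Compound 3 is expected at 6000 nM, with an estimated range of 1500 nM to 25000 nM.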

Compound 3, half-maximal inhibitory concentration: 9300 nM
Compound 3: middle estimate off by 1.6-fold (0.19 log units), on the low side; low and high end bracket the measured number.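

In this assay, trifluoromethyl on the phenoxy group, para to a large group, adds nothing that can be told from scatter (a 1.4-fold lower number from compound 2 to compound 3 (0.14 log units; within the scatter)). The phenoxy position thus accepts this added group without a clear shift, unlike the earlier exchange of cyano for phenoxy. The wider step (an at least 10-fold lower number from compound 1 to compound 3 (1.03 log units; beyond the scatter)) is therefore open-ended, and it gives no exact size: the limit of > 100000 nM in this assay, at which 1 of the 3 values shown sits.

From the compounds shown here alone, whether an amine, a carboxylic acid or a methoxy group at this place would shift the number remains open. So does whether trifluoromethyl elsewhere on that ring would.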